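Replacing a Butyl Chain with 3-Methylphenyl: Expected Clearance

A few compounds are considered here, and "the series" means these few. Any claim that something is new, unique, unknown or untested is made for them only; others in the source may bear on it.

Measured so far in an ADME assay on liver for metabolic stability, with Liver microsome (Homo sapiens) as the target, read by LC-MS, using microsomes; a lower number here means slower removal, a higher number faster removal of the compound:
- compound 1 `CC(C)(C)[C@@H](O)C(=O)N1CSC[C@H]1C(=O)NCc1cc(Cl)ccc1-n1cnnn1`: 120 mL.min-1.g-1
- compound 2 `CCCC[C@@H](O)C(=O)N1N=CC[C@H]1C(=O)NCc1cc(Cl)ccc1-n1cnnn1`: < 12 mL.min-1.g-1
- compound 3 `CC(C)(C)[C@@H](O)C(=O)N1OCC[C@H]1C(=O)NCc1cc(Cl)ccc1-n1cnnn1`: < 12 mL.min-1.g-1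

Compound 2 does not give a number here; its result is only a limit of this assay. Compound 3 likewise gives only a limit. Both therefore sit at the limit of < 12 mL.min-1.g-1 in this assay, at which 2 of the 3 values shown sit, while compound 1 stands clearly above them with a measured value.

Compound 4 `Cc1cccc([C@@H](O)C(=O)N2N=CC[C@H]2C(=O)NCc2cc(Cl)ccc2-n2cnnn2)c1` has not been measured yet. It differs from compound 2 by 3-methylphenyl in place of butyl on a saturated chain carbon bound to a carbonyl carbon and an oxygen on a saturated carbon.

Because compound 2 rests at < 12 mL.min-1.g-1, only a rise can be seen if one occurs. A small rise, possibly still within the scatter, is expected, so the step from compound 2 to compound 4 is estimated at an at least 1.6-fold higher number from compound 2 to compound 4 (0.22 log units; that floor lies within the scatter). Compound 4 is expected to give 20 mL.min-1.g-1, within a range of 8 mL.min-1.g-1 to 60 mL.min-1.g-1.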

Compound 4, intrinsic clearance in microsomes: < 12 mL.min-1.g-1
Compound 4: no number, only a limit (the forecaster's own chance of this, stated with the estimate: 35%); middle value at least 1.6-fold (0.22 log units) from the limit.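

Among the compounds shown here, compound 2 and compound 4 each give only a limit, so no step between them can be read: the limit of < 12 mL.min-1.g-1 in this assay, at which 3 of the 4 values shown sit.
As far as these compounds go, whether 3-methylphenyl in place of butyl changes the result in this assay at all, and by how much, remains open.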